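This account rests on a few compounds, and the source may have more. Where it says the series, first, only, none or still open, it means among the compounds named here.

Compounds measured so far:
compound 1 `COc1cc(C)cc(-c2nn(CC#N)cc2-c2ccc(-c3cccc(C(C)=O)c3)nc2)c1`: 77%
compound 2 `Cc1cc(O)cc(-c2nn(CC#N)cc2-c2ccnc(-c3ccc(Oc4ccccc4)cc3)c2)c1`: 86%
compound 3 `COc1cc(C)cc(-c2nn(CC#N)cc2-c2ccnc(-c3ccc(N(C)C)cc3)c2)c1`: 24%

The read-out is a functional assay on CCRF-CEM cells (Homo sapiens) for cytotoxicity, read by sulforhodamine B assay, with a stated time of 48 h, tested at 100 nM; a lower number here means a stronger effect, a higher number a weaker effect of the compound at the concentration tested. Among the three numbers compound 3 stands lowest, and so shows the strongest effect in this assay at the concentration tested; the nearest number belongs to compound 1 and lies higher by more than the scatter, the furthest to compound 2, also higher beyond the scatter. Among the measured compounds shown here, no two measured compounds differ in a single place, so no step has yet been measured for any one change.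

Compound 4 `Cc1cc(O)cc(-c2nn(CC#N)cc2-c2ccnc(-c3ccc(N(C)C)cc3)c2)c1` is not yet measured. It differs from compound 3 in one place: hydrogen in place of methyl on an oxygen on an aromatic ring. Cut one bond further out, the change reads methoxy to hydroxy, or 3-methoxy-5-methylphenyl to 3-hydroxy-5-methylphenyl. Compound 2 carries the hydroxy and methyl pattern, yet it differs from compound 3 in a second place as well; what compound 2 shows is 86%, and this cannot be read as the effect of the oxygen substituent alone.

The change removes a single carbon, and the expected step is a number 14 percentage points higher from compound 3 to compound 4 (beyond the scatter), a modest move toward a weaker effect, with the wide range allowing for a larger loss. Compound 4 is therefore estimated at 38%, within a range from 15% to 70%.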

Compound 4, a percentage reported as activity, at one concentration (the size of the read-out at that concentration, not a potency): 96%
Beside the measured number, compound 4's estimate is 58 percentage points below it; the whole stated range lies below it.
By their numbers in this assay, from the lowest: compound 3; then compounds 1, 2 and 4 (each within the scatter of the next, the first and the last beyond it).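

In this assay, among the compounds shown here, with the dimethylamino group held constant, hydrogen in place of methyl on an oxygen on an aromatic ring gives a number 72 percentage points higher from compound 3 to compound 4 (beyond the scatter), the first reading of a single change and a large one. The methyl on that oxygen therefore matters greatly to the effect of compound 3 at the concentration tested, and the low number of compound 3 cannot be credited to the dimethylamino group alone. With the 3-hydroxy-5-methylphenyl group held constant, dimethylamino in place of phenoxy on an aromatic carbon gives a number 10 percentage points higher from compound 2 to compound 4 (within the scatter), so no separate effect of that exchange can be read when the hydroxy group is present.

Nothing available explains the size of the methoxy to hydroxy step. On these data alone, it remains open whether an ethoxy group or a longer alkyl chain on that oxygen, or an amine in place of the methoxy group, keeps the effect, and whether the phenoxy group paired with methoxy behaves as dimethylamino does.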